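The source may hold more compounds than are shown below. What is called first, only, known or untested is meant among the compounds shown, and "the series" means these compounds.

Measured so far:
compound 1 `COc1ccc(C)cc1N1C(=O)CSC1c1cccc(C(=O)NCCCCc2ccccc2)c1` gives 79% in a functional assay on SJSA-1 cells (Homo sapiens) for inhibition, read by CCK-8 assay, with a stated time of 72 h, tested at 1 uM; a higher number here means more inhibition at the concentration tested (going by the name of the read-out), a lower number less inhibition;
compound 2 `COc1ccc(F)cc1N1C(=O)CSC1c1cccc(C(=O)NCCCCc2ccccc2)c1` gives 76% in this assay.

Compound 2 sits lower of these two numbers, but only by a number 3 percentage points lower from compound 1 to compound 2 (within the scatter), a step that stays within the scatter, so the two compounds cannot be told apart on these data. Compound 3 `Cc1cccc(N2C(=O)CSC2c2cccc(C(=O)NCCCCc3ccccc3)c2)c1` has not yet been measured in this assay. It differs from compound 2 in one place: 3-methylphenyl in place of 5-fluoro-2-methoxyphenyl on an amide-type nitrogen in a ring. Among the measured compounds shown here, the only step measured so far, a number 3 percentage points lower from compound 1 to compound 2 (within the scatter), also changed the ring on that same amide-type nitrogen, and it made no difference beyond the scatter. That step swapped one small group for another; the change to compound 3 exchanges the whole ring, so it is a looser guide. Compound 3 is therefore expected to change by a number 6 percentage points lower from compound 2 to compound 3 (within the scatter), nothing beyond the scatter. Compound 3 is estimated at 70%, between 50% and 88% in this assay.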

Compound 3, a percentage reported as inhibition, at one concentration (the size of the read-out at that concentration, not a potency): 84%
The estimate for compound 3 lay 14 percentage points below the measured number; the measured number falls inside the stated range.
By their numbers in this assay, from the lowest: compounds 2, 1 and 3 (each within the scatter of the next).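

In this assay, the ring on the amide-type nitrogen accepts a larger change than the earlier pair showed: 3-methylphenyl in place of 5-fluoro-2-methoxyphenyl gives a number 8 percentage points higher from compound 2 to compound 3 (within the scatter), even though the fluoro and the methoxy both leave at once. The methoxy on its own also proves dispensable, as hydrogen in its place gives a number 5 percentage points higher from compound 1 to compound 3 (within the scatter), so no oxygen on this ring is needed to keep the read-out in this range. Nothing available explains why these rings read alike.

All three compounds keep a carbon-only aromatic ring at this position, which leaves open how a ring carrying an amine or a carboxylic acid, or a saturated cyclohexyl ring, would fare. The phenylbutyl chain on the other amide also stays the same throughout, so a shorter or longer chain remains an open question.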